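Shortening the side-chain ester in compound 1

This account rests on a few compounds, and the source may have more. Where it says the series, first, only, none or still open, it means among the compounds named here.

Compound 1 `O=C(CN(c1ncnc2c1ncn2C1CCCCO1)C1CC1)N[C@@H](CCC(=O)OCc1ccccc1)C(=O)OCc1ccccc1` stands lowest of the two measured numbers: in a functional assay on the whole organism (Tail, strain ICR) with Mus musculus as the target, in the tail flick test, with a stated time of 90 min, at a dose of 25 umol/kg by the oral route (a higher number here means a stronger effect of the compound at the dose given, a lower number a weaker effect), compound 1 gives 25.2%. Among the measured compounds shown here, compound 2 `O=C(OCc1ccccc1)[C@@H]1CCCN1C(=O)CN(c1nc(Cl)nc2[nH]cnc12)C1CC1` gives 43.3% in this assay, a number beyond the scatter above compound 1, but the two structures differ in more than one place, so no single step is read from them.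

Compound 3 `O=C(CN(c1ncnc2c1ncn2C1CCCCO1)C1CC1)N[C@@H](CC(=O)OCc1ccccc1)C(=O)OCc1ccccc1` keeps the core of compound 1 and changes only the amino acid part: benzyloxycarbonyl in place of (benzyloxycarbonyl)methyl on a saturated chain carbon, two bonds along the chain from an amide-type nitrogen and a carbonyl carbon. Cut one bond further out, the same change reads 2-(benzyloxycarbonyl)ethyl to (benzyloxycarbonyl)methyl.

For the measured compounds named here, no step of this kind has been measured. The change is expected to move this assay little, so the step of a number 1.8 percentage points higher from compound 1 to compound 3 (within the scatter) is estimated to stay within the scatter, in either direction. Compound 3 is therefore estimated at 27% in this assay, with a range from 12% to 45%.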

Compound 3, a percentage reported as activity, at one dose (the size of the read-out at that dose, not a potency): 25.1%
Compound 3: the middle estimate sits 1.9 percentage points above what was measured, within the range that was stated.
By their numbers in this assay, from the lowest: compounds 3 and 1 (each within the scatter of the next); then compound 2.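

Among the compounds shown here, the step of a number 0.1 percentage points lower from compound 1 to compound 3 (within the scatter) in this assay is the first single-place comparison. On a saturated chain carbon, two bonds along the chain from an amide-type nitrogen and a carbonyl carbon, benzyloxycarbonyl therefore reads as equivalent to (benzyloxycarbonyl)methyl at this one dose and time. No measurement is available that would explain this result.

Both compounds keep a benzyl ester at this position, so a free carboxylic acid, an amide or a chain longer than 2-(benzyloxycarbonyl)ethyl would test whether the position tolerates more than a change in chain length. The steps from compound 2 to compound 1 and compound 3 cannot be read because they differ in more than one place, leaving the contributions of the amino acid part and the core unseparated.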